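Methoxy for hydrogen on the aromatic carbon of compound 1

The source may hold more compounds than are shown below. What is called first, only, known or untested is meant among the compounds shown, and "the series" means these compounds.

Three members of the series have so far been measured in a functional assay on A549 cells (Homo sapiens) for antiproliferative activity, with a stated time of 72 h, tested at 50 ug/mL; on this read-out higher numbers stand for a stronger effect at the one concentration tested and lower numbers for a weaker effect. Compound 1 `O=c1[nH]nc2n(c1=O)CCN2c1ccccc1` gives 17%, which places it second highest of the three numbers: compound 3 `N=c1c(=O)[nH]nc2n1CCN2c1ccccc1Cl` gives 16%, a value within the scatter of that of compound 1, while compound 2 `Cc1ccc(N2CCn3c2n[nH]c(=O)c3=O)cc1` gives 31%, the highest of the three. Among the measured compounds shown here, the only single-change step available, a number 14 percentage points higher from compound 1 to compound 2 (beyond the scatter), came from methyl in place of hydrogen on an aromatic carbon.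

Compound 4 `COc1ccccc1N1CCn2c1n[nH]c(=O)c2=O` is not yet measured. It differs from compound 1 by methoxy in place of hydrogen on an aromatic carbon. For the measured compounds named here, no measured step covers a methoxy, nor any change ortho to a large group, so the methyl step is the only guide, and it sits on a different aromatic carbon. Going by the values given here, compound 3 carries a halogen ortho to a large group but also a different core, so its value of 16% shows only that such a compound lands near compound 1.

A modest upward step is therefore expected for compound 4, a number 5 percentage points higher from compound 1 to compound 4 (within the scatter), smaller than the methyl step and possibly within the scatter. Compound 4 is estimated at 22% in this assay, with a range from 8% to 40%.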

Compound 4, a percentage reported as inhibition, at one concentration (the size of the read-out at that concentration, not a potency): 39%
Compound 4: the middle estimate sits 17 percentage points below what was measured; low and high end bracket the measured number.
By their numbers in this assay, from the lowest: compounds 3 and 1 (each within the scatter of the next); then compounds 2 and 4 (each within the scatter of the next).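

In this assay, methoxy in place of hydrogen on an aromatic carbon, ortho to a large group, gives a number 22 percentage points higher from compound 1 to compound 4 (beyond the scatter) and so shows that a substituent at this place on the core of compound 1 can go with a higher number. Alongside a number 14 percentage points higher from compound 1 to compound 2 (beyond the scatter) it also shows that an upward step beyond the scatter is not confined to methyl, and compound 3 could not show this for the ortho place since its core also differs. Nothing measured here accounts for the gain.

The compounds shown do not separate the contribution of the methoxy from that of its place, which would take methoxy on another aromatic carbon and a methyl or chlorine ortho to the large group on the same core as compound 1. From the compounds shown here alone, whether the gain extends to a hydroxy, an ethoxy or an amine at this place remains open, and each number here tells only of a stronger or weaker effect at the one concentration tested.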